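Two limits and an unmeasured chain olefin

The compounds below may be only part of what the source reports. "The series", "measured", "known", "first", "only" and "open" are said of these compounds alone.

Measured so far:
compound 1 `CCCC[C@](C)(OC)[C@H](O)/C=C/C1[C@H](O)CC(=O)[C@@H]1C/C=C\CCCC(=O)OC` — > 1 mg/kg
compound 2 `CCCC[C@@](C)(OC)[C@H](O)/C=C/C1[C@H](O)CC(=O)[C@@H]1CCCCCCC(=O)OC` — > 2.5 mg/kg

The read-out is a functional assay on the whole organism (Cricetulus griseus) with Cricetinae gen. sp. as the target; a higher number here means that more compound is needed for the effect, a lower number that less compound is needed. Compound 1 gives in this assay only a limit, > 1 mg/kg, not a number. Compound 2 likewise gives only a limit in this assay, > 2.5 mg/kg. Thus compound 2 stands at a limit, and the one other value shown is a limit as well: the limit of > 2.5 mg/kg in this assay, at which 1 of the 2 values shown sits, and (the limit of > 1 mg/kg in this assay, at which 1 of the 2 values shown sits). Going by the values given here, no step between measured compounds is available.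

Compound 3 `CCCC[C@@](C)(OC)[C@H](O)/C=C/C1[C@H](O)CC(=O)[C@@H]1C/C=C\CCCC(=O)OC` differs from compound 2 in one place: 5-(methoxycarbonyl)pent-1-en-1-yl in place of 5-(methoxycarbonyl)pentyl on a saturated chain carbon bound to a saturated ring carbon. With both measured values being limits, no step beyond the usual scatter in this assay is expected from compound 2 to compound 3, and the outcome is expected to be another limit rather than a number. Compound 3 is estimated at 3 mg/kg in this assay, within 1 mg/kg to 10 mg/kg, which implies an expected step that the limit leaves unreadable from compound 2 to compound 3.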

Compound 3, dose for half-maximal effect: > 1 mg/kg
Compound 3 ended at the assay's limit; the forecaster's own chance of this, stated with the estimate: 70%; the middle value does not contradict the limit.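

Going by these compounds alone, compound 1, compound 2 and compound 3 all stand as limits, not numbers, so neither the step from compound 2 to compound 3 nor the one from compound 1 to compound 3 can be read. Going by these compounds, whether the chain double bond or the stereocentre at the saturated chain carbon alters the dose needed remains open.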